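The compounds below may be only part of what the source reports. "The series", "measured", "known", "first", "only" and "open" are said of these compounds alone.

Measured compounds:
- compound 1 `O=C(O)Cc1nn(Cc2nc3cc(F)cc(F)c3s2)c(=O)c2cccnc12`: 68%
- compound 2 `O=C(O)Cc1nn(Cc2nc3ccccc3s2)c(=O)c2ccccc12`: 67%
- compound 3 `Cc1c(CC(=O)O)nn(Cc2nc3cc(C(F)(F)F)ccc3s2)c(=O)c1C`: 81%

In a functional assay on the whole organism (Sciatic nerve) for inhibition, with Rattus norvegicus as the target, at a dose of 25 mg/kg (on this read-out higher numbers stand for more inhibition at the one dose given (going by the name of the read-out) and lower numbers for less inhibition), compound 1 gives 68% and stands second highest of the three numbers. Its nearest neighbour is compound 2 with 67%, a difference that lies within the usual scatter, so the two cannot be told apart on this read-out. The furthest is compound 3 with 81%, which lies beyond the scatter above compound 1. Among the measured compounds shown here, no pair among the measured compounds differs in only one place, so no single-change step is known for the series.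

Compound 4 `O=C(O)Cc1nn(Cc2nc3cc(F)ccc3s2)c(=O)c2cccnc12` is the unmeasured member. It differs from compound 1 in one place: hydrogen in place of fluoro on an aromatic carbon. Nothing measured covers this kind of change, so the size of the step rests on general expectation only. Removing a single fluoro on the fused ring system of the side chain is expected to leave the read-out close to that of compound 1, with a step no larger than the scatter and, if anything, slightly downward. For compound 4 the expected value in this assay is 62%, with a range from 45% to 78%. The step from compound 1 to compound 4 that this estimate means is a number 6 percentage points lower from compound 1 to compound 4 (within the scatter), expected to fall within the scatter.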

Compound 4, a percentage reported as inhibition, in the whole organism at one dose (the size of the read-out at that dose, not a potency): 64%
The estimate for compound 4 lay 2 percentage points below the measured number, and the stated range covers the measured number.
By their numbers in this assay, from the lowest: compounds 4, 2 and 1 (each within the scatter of the next); then compound 3.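

The series now has its first single-change step. In this assay, hydrogen in place of fluoro on an aromatic carbon, ortho to a fused ring and meta to a fluoro group, gives a number 4 percentage points lower from compound 1 to compound 4 (within the scatter) and so leaves compound 4 indistinguishable from compound 1 on this read-out at the one dose given; at this position, the fluoro group is not required for the level of inhibition seen with compound 1. No measured property accompanies this step, and nothing shown explains why the two compounds read alike.

Still open, from the compounds shown here alone, is whether a chloro, methoxy or amine group at this position would also leave the read-out unchanged, and whether the remaining fluoro group, meta to the one removed, can be replaced by hydrogen in the same way. A single reading at one dose also gives no potency, so a difference between compound 1 and compound 4 could still appear at other doses.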